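Changing the imine carbon in a thiosemicarbazone series

The source may hold more compounds than are shown below. What is called first, only, known or untested is meant among the compounds shown, and "the series" means these compounds.

Measured compounds:
- compound 1, `CC1=CC[C@@H]([C@@](C)(O)CCCC(C)(C)NC(=S)N/N=C\c2ccccc2)CC1`: 43600 nM
- compound 2, `CC1=CC[C@@H]([C@@](C)(O)CCCC(C)(C)NC(=S)N/N=C\c2ccc(N(C)C)cc2)CC1`: > 100000 nM
- compound 3, `CC1=CC[C@@H]([C@@](C)(O)CCCC(C)(C)NC(=S)N/N=C\c2cccc([N+](=O)[O-])c2)CC1`: > 100000 nM

Going by the values given here, in a functional assay on OVCAR-3 cells (Homo sapiens) for cytotoxicity, read by sulforhodamine B assay (on this read-out higher numbers stand for lower toxicity in this test and lower numbers for higher toxicity in this test), compound 1 gives 43600 nM, which is the only actual number in this set. Compound 2 reaches only a limit of the assay, > 100000 nM. Compound 3 likewise reaches only a limit, > 100000 nM. Both steps, an at least 2.2-fold higher number from compound 1 to compound 2 (0.36 log units; beyond the scatter) and an at least 2.2-fold higher number from compound 1 to compound 3 (0.36 log units; beyond the scatter), add a group to the aromatic ring and move the value to the limit of > 100000 nM in this assay, at which 2 of the 3 values shown sit.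

Compound 4, `CC1=CC[C@@H]([C@@](C)(O)CCCC(C)(C)NC(=S)N/N=C(/C)c2ccccc2)CC1`, is not yet measured. It differs from compound 1 by a group of 9 heavy atoms (8 carbon, 1 nitrogen; one six-membered aromatic ring of carbon only) in place of a group of 8 heavy atoms (7 carbon, 1 nitrogen; one six-membered aromatic ring of carbon only), on an amide-type nitrogen; the aromatic ring itself is left unchanged. Among the compounds with values here, neither measured step touches this place, so there is no direct precedent. With the ring kept as in compound 1, the expectation for compound 4 is no step beyond the scatter, a 1.1-fold higher number from compound 1 to compound 4 (0.06 log units; within the scatter). The estimated value for compound 4 is therefore 50000 nM, with a range from 20000 nM to 150000 nM.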

Compound 4, concentration lethal to 50% of the cells: > 100000 nM
Compound 4 gave a limit, no number (the forecaster's own chance of this, stated with the estimate: 35%); middle value at least 2.0-fold (0.30 log units) from the limit.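

The change on the amide-type nitrogen leaves the aromatic ring as it is, yet it gives an at least 2.2-fold higher number from compound 1 to compound 4 (0.36 log units; beyond the scatter) in this assay. Going by these compounds alone, the earlier steps changed only the aromatic ring, so this is the first sign that the read-out also responds to a change outside that ring, here a group of 9 heavy atoms in place of a group of 8. Compound 1 remains the only compound with an actual number, and the steps among compound 2, compound 3 and compound 4 cannot be read: the limit of > 100000 nM in this assay, at which 3 of the 4 values shown sit.

The compounds shown leave open how an ethyl group or another longer chain in this same place would read. They also leave open what an amine or a carboxylic acid on the aromatic ring of compound 1 would do to the read-out.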